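Two aryl variants on one dioxane-linked pyridine scaffold

The source may hold more compounds than are shown below. What is called first, only, known or untested is meant among the compounds shown, and "the series" means these compounds.

This account follows two compounds built on a shared core carrying a pyridine, a hexenoic acid chain and an aryl group on an oxygen on a saturated carbon. Compound 1 `O=C(O)CC/C=C\CC1COC(c2ccc(C(F)(F)F)cc2)OC1c1cccnc1` gives 44 nM in an assay for inhibition of Thromboxane-A synthase (Homo sapiens), using microsomes; a higher number here means a weaker inhibitor, a lower number a stronger inhibitor. Compound 2 `CC(C)(Oc1ccc(F)cc1)C1OCC(C/C=C\CCC(=O)O)C(c2cccnc2)O1` gives 51 nM in this assay, a number within the scatter of that of compound 1, so the two cannot be told apart on these data. Compound 3 `COc1ccc(OC(C)(C)C2OCC(C/C=C\CCC(=O)O)C(c3cccnc3)O2)c([N+](=O)[O-])c1` has not been measured; it differs from compound 2 by 4-methoxy-2-nitrophenyl in place of 4-fluorophenyl on an oxygen on a saturated carbon. Within the data shown here, no measured pair shows what such a swap does, so the step is expected to be small and its direction is open. Compound 3 is estimated at 70 nM in this assay, within 25 nM to 200 nM, a change of a 1.4-fold higher number from compound 2 to compound 3 (0.14 log units; within the scatter).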

Compound 3, half-maximal inhibitory concentration: 37 nM
For compound 3 the middle estimate is 1.9-fold (0.28 log units) above the measured one; the measured number falls inside the stated range.
By their numbers in this assay, from the lowest: compounds 3, 1 and 2 (each within the scatter of the next).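

Among these compounds, on an oxygen on a saturated carbon, the swap of 4-fluorophenyl for 4-methoxy-2-nitrophenyl gives the first measured step at this position in this assay, a 1.4-fold lower number from compound 2 to compound 3 (0.14 log units; within the scatter), and that step lies within the scatter. The entering group has 11 heavy atoms against 7 and 3 hydrogen-bond acceptors against 0, yet on these data the position accepts it with no change that can be told from the scatter. Nothing at hand offers an explanation for this result.

The methoxy and nitro groups enter together in this one step, so what each does alone remains unresolved. Also open, from the compounds shown here alone, is whether an amine in place of the nitro group, or a longer chain in place of the methoxy group, would give a step beyond the scatter.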